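A few compounds are considered here, and "the series" means these few. Any claim that something is new, unique, unknown or untested is made for them only; others in the source may bear on it.

Compound 3 `COc1n[nH]c2ncc(-c3cn(-c4c(F)ccc(NC(=O)c5cccc(Cl)c5)c4F)nn3)cc12` gives the highest number of the three compounds measured in an assay on Sf9 cells for inhibition of mitogen-activated protein kinase kinase kinase 20 (Homo sapiens), read by ADP-Glo, with a stated time of 30 min; on this read-out higher numbers stand for weaker inhibition and lower numbers for stronger inhibition: compound 3 gives 54.3 nM. Compound 2 `Nc1ccc(-c2cn(-c3c(F)ccc(NS(=O)(=O)c4cccc(Cl)c4)c3F)nn2)cn1` gives 46.2 nM, which lies within the scatter of compound 3. Compound 1 `COc1n[nH]c2ncc(-c3cn(-c4c(F)ccc(NS(=O)(=O)c5cccc(Cl)c5)c4F)nn3)cc12` gives 1.9 nM, far lower than either.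

Compound 4 `COc1n[nH]c2ncc(-c3cn(-c4c(F)ccc(NS(=O)(=O)c5ccccc5)c4F)nn3)cc12` differs from compound 3 in one place: phenylsulfonyl in place of (3-chlorophenyl)carbonyl on a nitrogen on an aromatic ring. Two measured steps help here. The change from compound 1 to compound 3 replaced the sulfonyl by the carbonyl on that same nitrogen and gave a 29-fold higher number from compound 1 to compound 3 (1.46 log units; beyond the scatter). The change from compound 1 to compound 2 altered the core instead and gave a 24-fold higher number from compound 1 to compound 2 (1.39 log units; beyond the scatter); it does not touch the group changed here. Among the measured compounds shown here, the step to compound 4 reverses the carbonyl-for-sulfonyl change but also removes the chlorine from the phenyl ring, and no measured pair shows the effect of that chlorine alone. A large drop in number is therefore expected, but with less certainty than the reversal alone would give. The estimated step is an 11-fold lower number from compound 3 to compound 4 (1.04 log units; beyond the scatter). Compound 4 is expected to give 5 nM, with a range from 1.5 nM to 20 nM.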

Compound 4, half-maximal inhibitory concentration: 3.8 nM
Estimate against measurement, compound 4: 1.3-fold (0.12 log units) above; the measured number falls inside the stated range.
By their numbers in this assay, from the lowest: compounds 1 and 4 (each within the scatter of the next); then compounds 2 and 3 (each within the scatter of the next).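

Among the compounds shown here, with the sulfonyl kept, hydrogen in place of chloro on the phenyl ring gives a 2.0-fold higher number from compound 1 to compound 4 (0.30 log units; within the scatter), so this pair isolates the chlorine for the first time and shows no change beyond the scatter. The step to phenylsulfonyl from (3-chlorophenyl)carbonyl gives a 14-fold lower number from compound 3 to compound 4 (1.16 log units; beyond the scatter), and it changes two things at once, yet since losing the chlorine shifts the number so little among the sulfonyl compounds, the sulfonyl in place of the carbonyl is the likelier source of this large step. Nothing available explains why that exchange on the nitrogen matters so much.

Whether the chlorine is equally dispensable among the carbonyl compounds stays open, as the phenylcarbonyl counterpart of compound 3 is not among those shown. Also open, on these data alone, is how a methyl or a short alkyl chain in place of the phenyl ring on the sulfonyl would read out.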